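Amide variation on a thiazole antagonist series

The source may report more compounds than this note shows. Statements on the series, on what has been measured and on what is new or still open speak of the compounds shown alone.

Compound 1 `CC1Cc2ccccc2N1C(=O)c1sc(-c2ccc(S(C)(=O)=O)c([N+](=O)[O-])c2)nc1C(F)(F)F` gives 5200 nM in a functional assay for antagonist activity at thyroid hormone receptor beta (Homo sapiens), read by fluorescence polarization, with a stated time of 3 h; on this read-out lower numbers stand for stronger inhibition and higher numbers for weaker inhibition.
Compound 2 `CN(Cc1ccccc1)C(=O)c1sc(-c2ccc(S(C)(=O)=O)c([N+](=O)[O-])c2)nc1C(F)(F)F` gives 3300 nM in this assay.

Compound 2 stands at the lower of the two numbers in this assay, with compound 1 closest. Compound 3 `CS(=O)(=O)c1ccc(-c2nc(C(F)(F)F)c(C(=O)N3CCCCC3)s2)cc1[N+](=O)[O-]` differs from compound 2 in one place: piperidin-1-yl in place of benzyl(methyl)amino on a carbonyl carbon. Among the measured compounds shown here, the only step that bears on this amide position is a 1.6-fold lower number from compound 1 to compound 2 (0.20 log units; within the scatter), which stayed within the scatter. The step of a 1.4-fold higher number from compound 2 to compound 3 (0.13 log units; within the scatter) is therefore expected to be no more than a modest change in this assay. Compound 3 is expected to give about 4500 nM, within a range from 1500 nM to 14000 nM.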

Compound 3, half-maximal inhibitory concentration: 660 nM
Estimate against measurement, compound 3: 6.8-fold (0.83 log units) above; measured number outside the range, below it.
By their numbers in this assay, from the lowest: compound 3; then compounds 2 and 1 (each within the scatter of the next).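

In this assay this amide position can move the number beyond the scatter, which the earlier step within the scatter did not show: the change gives a 5.0-fold lower number from compound 2 to compound 3 (0.70 log units; beyond the scatter) and also a 7.9-fold lower number from compound 1 to compound 3 (0.90 log units; beyond the scatter). Piperidin-1-yl, with its six-membered non-aromatic ring, thus stands apart from both larger amide groups. Nothing measured here explains this difference. The compounds shown leave open whether the gain belongs to piperidine alone or would persist with a pyrrolidine or morpholine ring on the carbonyl carbon.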